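The source may hold more compounds than are shown below. What is called first, only, known or untested is meant among the compounds shown, and "the series" means these compounds.

Measured so far in a functional assay on A549 cells (Homo sapiens) for antiproliferative activity, read by MTT assay, with a stated time of 48 h; a lower number here means a stronger inhibitor, a higher number a weaker inhibitor:

- compound 1 `O=C(/C=C\Nc1ccc(Cl)cc1)c1cn(-c2ccccc2)nc1-c1ccc(F)cc1`: 6700 nM
- compound 2 `O=C(/C=C\Nc1ccc(O)cc1)c1cn(-c2ccccc2)nc1-c1ccc(F)cc1`: 1500 nM

Going by the values given here, compound 2 gives the lowest number of the two, and its one neighbour is compound 1; the step of a 4.5-fold lower number from compound 1 to compound 2 (0.65 log units; beyond the scatter) is the only measured comparison in the set.

The next compound, compound 3 `COc1ccc(N/C=C\C(=O)c2cn(-c3ccccc3)nc2-c2ccc(F)cc2)cc1`, keeps the whole frame of compound 2 and differs by methyl in place of hydrogen on an oxygen on an aromatic ring. Among the compounds with values here, no measured pair in the set carries this change; the only measured step, a 4.5-fold lower number from compound 1 to compound 2 (0.65 log units; beyond the scatter), concerns a different exchange at the same aromatic position and shows that changes to this ring can move this assay by a modest amount. It does not show the direction for a methoxy in place of a hydroxy. With nothing closer to rest on, the expectation is that compound 3 lands near compound 2, with the expected step of a 1.7-fold higher number from compound 2 to compound 3 (0.22 log units; within the scatter) small and not clearly beyond the scatter, though a somewhat higher number is counted as the more likely side. The estimate for compound 3 in this assay is 2500 nM, with a range from 900 nM to 7000 nM.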

Compound 3, half-maximal inhibitory concentration: 8900 nM
Estimate against measurement, compound 3: 3.6-fold (0.55 log units) below; measured number outside the range, above it.
By their numbers in this assay, from the lowest: compound 2; then compounds 1 and 3 (each within the scatter of the next).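

In this assay, methyl in place of hydrogen on the oxygen gives a 5.9-fold higher number from compound 2 to compound 3 (0.77 log units; beyond the scatter), so the lower number seen with hydroxy does not survive conversion to methoxy. The methoxy and chloro compounds cannot be told apart, with a 1.3-fold higher number from compound 1 to compound 3 (0.12 log units; within the scatter), which leaves compound 2 as the only one of the three standing apart, with its steps to both others beyond the scatter. This pattern rests on three compounds that vary at one place on one ring, and nothing available here bears on why the hydroxy compound differs from the other two.

Still open, as far as these compounds go, is whether the hydrogen on the oxygen is what matters or whether hydroxy is simply one of several groups that give a lower number here; an amine or a carboxylic acid on the same aromatic carbon, or ethoxy as a longer chain on the oxygen, would help separate these readings. Also open, from the compounds shown here alone, is whether the same order among hydroxy, methoxy and chloro holds when the shared core is changed elsewhere.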